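From Phenyl to Cyclopropyl on the Side Chain

The source may report more compounds than this note shows. Statements on the series, on what has been measured and on what is new or still open speak of the compounds shown alone.

Compound 3 `O/N=C(/NCc1ccccc1)c1ccc2occc2c1` stands at the weak end of the numbers obtained so far in an assay on tissue (HeLa cells) for inhibition of Indoleamine 2,3-dioxygenase 1 (Homo sapiens), read by spectrophotometry (a lower number here means a stronger inhibitor, a higher number a weaker inhibitor), where compound 3 gives 28200 nM. Its nearest neighbour is compound 2 `O/N=C(/Nc1ccc(F)c(Cl)c1)c1ccc2occc2c1`, which in this assay gives 1800 nM, a gap beyond the scatter. Compound 1 `O/N=C(/Nc1ccc(Cl)cc1)c1ccc2occc2c1` reaches only a limit of the assay in this assay, > 30000 nM (the limit of > 30000 nM in this assay, at which 1 of the 3 values shown sits). Compound 4 `O/N=C(/NCC1CC1)c1ccc2occc2c1` differs from compound 3 by cyclopropyl in place of phenyl on a saturated chain carbon bound to an amine nitrogen. Among the measured compounds shown here, no measured pair shows this change. The step is expected to be a 1.1-fold higher number from compound 3 to compound 4 (0.03 log units; within the scatter), none beyond the scatter, with a real risk that the assay reports only a limit. Compound 4 is therefore expected to give about 30000 nM in this assay, within 10000 nM to 100000 nM.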

Compound 4, half-maximal inhibitory concentration: > 30000 nM
Compound 4: no number, only a limit (the forecaster's own chance of this, stated with the estimate: 55%); the middle value sits exactly at the limit.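

Replacing phenyl with cyclopropyl on a saturated chain carbon bound to an amine nitrogen gives an at least 1.0-fold higher number from compound 3 to compound 4 (0.02 log units; that floor lies within the scatter) in this assay, so this change brings no gain at this position. As far as these compounds go, compound 4 gives only a limit, and the true size of the step remains unknown. Limits now recur among the values shown: the limit of > 30000 nM in this assay, at which 2 of the 4 values shown sit.

Still open, from the compounds shown here alone, is whether an amine, a carboxylic acid or a longer chain in place of cyclopropyl would give a measurable number. Going by these compounds, it is also open whether the fluoro and chloro substituents of compound 2 would alter the value of compound 3 if placed on its phenyl.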